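A Second Chloro Group on the Shared Core

A few compounds are considered here, and "the series" means these few. Any claim that something is new, unique, unknown or untested is made for them only; others in the source may bear on it.

In a functional assay on UACC-257 cells (Homo sapiens) for cytotoxicity, read by sulforhodamine B assay, with a stated time of 48 h (on this read-out lower numbers stand for stronger inhibition of growth and higher numbers for weaker inhibition of growth), compound 1 `ClCc1cccc(Cn2cnc3ncnc(Cl)c32)c1` gives 5490 nM. Compound 2 `ClCc1cccc(Cn2cnc3c(Cl)ncnc32)c1` gives 37200 nM, and compound 3 `ClCc1cccc(Cn2cnc3c(Cl)nc(Cl)nc32)c1` gives 3460 nM. Among these three, compound 1 sits close to compound 3, the two numbers lying within the usual scatter of each other, while compound 2 stands well above both.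

Compound 4 `ClCc1cccc(Cn2cnc3nc(Cl)nc(Cl)c32)c1` has not yet been measured. It differs from compound 1 in one place: chloro in place of hydrogen on an aromatic carbon. A closely related step is already known: an 11-fold lower number from compound 2 to compound 3 (1.03 log units; beyond the scatter). That step added a chloro group at the same kind of place, between two ring nitrogen atoms, on a core that already carried one chloro group. On that basis the step from compound 1 to compound 4 is expected to lower the number in this assay, though perhaps less sharply, since compound 1 already gives 5490 nM, a much lower starting point than compound 2. The estimate for compound 4 is 1500 nM, with a range from 500 nM to 5000 nM, meaning an expected step of a 3.7-fold lower number from compound 1 to compound 4 (0.56 log units; beyond the scatter).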

Compound 4, concentration for total growth inhibition: 15100 nM
Compound 4: the middle estimate sits 10-fold (1.00 log units) below what was measured, and the stated range ends below it.
By their numbers in this assay, from the lowest: compounds 3 and 1 (each within the scatter of the next); then compound 4; then compound 2.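

Placed between two ring nitrogen atoms, chloro in place of hydrogen now gives a 2.8-fold higher number from compound 1 to compound 4 (0.44 log units; beyond the scatter) in this assay, so this change does not act in a single direction at this position. The earlier step alone pointed to a general gain in growth inhibition, and the new step does not support that reading. The outcome depends on the core that receives the chloro group, and a step seen on one core cannot simply be carried over to another: the same change on two cores in this assay, an 11-fold lower number (1.03 log units; beyond the scatter) from compound 2 to compound 3 and a 2.8-fold higher number (0.44 log units; beyond the scatter) from compound 1 to compound 4, 30-fold (1.47 log units) apart, beyond the scatter of two such steps

The compounds shown leave open whether a different group at this position, such as an amine or a methoxy group, would also split between the two cores. They also do not tell why the two cores respond differently to the same change.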